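A few compounds are considered here, and "the series" means these few. Any claim that something is new, unique, unknown or untested is made for them only; others in the source may bear on it.

Compound 1 `COc1cc(-c2cc(/C=C/C(=O)c3ccc(N)cc3)[nH]n2)cc(OC)c1OC` stands highest of the two numbers in a functional assay on A549 cells (Homo sapiens) for cytotoxicity, read by sulforhodamine B assay, with a stated time of 48 h, tested at 100 uM (a lower number here means a stronger effect, a higher number a weaker effect of the compound at the concentration tested), where compound 1 gives -52%; compound 2 `COc1ccc(-c2cc(/C=C/C(=O)c3ccc(N)cc3)[nH]n2)cc1OC` gives -76%. Going by the values given here, the one measured step, a number 24 percentage points lower from compound 1 to compound 2 (beyond the scatter), concerns a different part of the structure and therefore does not bear on the change to compound 3 `COc1cc(-c2cc(/C=C/C(=O)c3ccc(F)c(F)c3)[nH]n2)cc(OC)c1OC`, which is 3,4-difluorophenyl in place of 4-aminophenyl on a carbonyl carbon. Among the compounds with values here, no measured step covers this exchange, so the direction is open. Compound 3 is estimated at -50%, within -90% to -10%. The expected step is accordingly a number 2 percentage points higher from compound 1 to compound 3 (within the scatter), nothing beyond the usual scatter.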

Compound 3, a percentage reported as activity, at one concentration (the size of the read-out at that concentration, not a potency): -15%
Compound 3: the middle estimate sits 35 percentage points below what was measured; the measured number falls inside the stated range.
By their numbers in this assay, from the lowest: compound 2; then compound 1; then compound 3.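

In this assay, 3,4-difluorophenyl in place of 4-aminophenyl on a carbonyl carbon gives a number 37 percentage points higher from compound 1 to compound 3 (beyond the scatter) and thus a weaker effect. The group on the carbonyl carbon therefore matters in this series, a point the earlier step on the methoxy group could not show. Nothing measured here accounts for this change.

Going by these compounds, it remains open whether a 4-hydroxyphenyl or a 4-fluorophenyl group at this position would read closer to compound 1 or to compound 3. On these data alone, whether the exchange has the same effect with the dimethoxyphenyl group of compound 2 is also open.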